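This account rests on a few compounds, and the source may have more. Where it says the series, first, only, none or still open, it means among the compounds named here.

Compound 1, `CC(=O)c1ccc(NC(=O)CN(C(=O)c2ccccc2)S(=O)(=O)c2ccc(C)cc2)cc1`: 17.9%
Compound 2, `CC(=O)c1ccc(NC(=O)C2CC(O)CN2S(=O)(=O)c2ccc(C)cc2)cc1`: 12.4%
Compound 3, `CC(=O)c1ccc(NC(=O)CN(C(=O)c2ccccc2)S(=O)(=O)c2ccccc2)cc1`: 40.5%

These three compounds were all tested in a functional assay for inhibition, read by spectrophotometry, with a stated time of 20 min, tested at 1 mg/mL; on this read-out higher numbers stand for a stronger effect at the one concentration tested and lower numbers for a weaker effect. Among them compound 2 gives the lowest of the three numbers: its gap to compound 1 stays within the usual scatter of such measurements, while compound 3 stands well beyond it. Compound 4, `CC(=O)c1ccc(NC(=O)C2CC(O)CN2S(=O)(=O)c2ccccc2)cc1`, has not yet been measured. It differs from compound 2 in a single place: hydrogen in place of methyl on an aromatic carbon. For the measured compounds named here, one measured step bears directly on this change, since the same swap was made on the pair of compound 1 and compound 3, and there it gave a number 22.6 percentage points higher from compound 1 to compound 3 (beyond the scatter), a modest shift that lies beyond the scatter. Nothing else in the structure is altered, so a step of roughly that size, and in the same upward direction, is expected for compound 4 in this assay. Compound 4 is therefore estimated at 33%, with a range from 15% to 52%. Going by the values given here, the expected step is a number 20.6 percentage points higher from compound 2 to compound 4 (beyond the scatter), and the range is kept wide because a number 22.6 percentage points higher from compound 1 to compound 3 (beyond the scatter) is the only comparison of this kind available.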

Compound 4, a percentage reported as inhibition, at one concentration (the size of the read-out at that concentration, not a potency): 40.2%
Beside the measured number, compound 4's estimate is 7.2 percentage points below it; measured number inside the range.
By their numbers in this assay, from the lowest: compounds 2 and 1 (each within the scatter of the next); then compounds 4 and 3 (each within the scatter of the next).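

Going from 4-methylphenyl to phenyl in this assay gives a number 27.8 percentage points higher from compound 2 to compound 4 (beyond the scatter), so the rise now appears on a second core. Before this result the change had been seen on a single pair, and the rise could have been peculiar to that one core. Now it appears on both cores shown, with steps that match in size: the same change on two cores in this assay, a number 22.6 percentage points higher (beyond the scatter) from compound 1 to compound 3 and a number 27.8 percentage points higher (beyond the scatter) from compound 2 to compound 4, 5.2 percentage points apart, within the scatter of two such steps. Across these four compounds, then, swapping methyl for hydrogen at this place on the ring raises the number whichever core carries it, and no pair shown goes against that.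

Only hydrogen and methyl occupy this place in the compounds shown, so it stays open what a chlorine, a methoxy group, an amine or a carboxylic acid would do there. Each number is also a reading at a single concentration, which gives the size of the effect rather than a potency, and the data do not tell why this change moves the number.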